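Ester variants: cyclopentyl next in the series

A few compounds are considered here, and "the series" means these few. Any claim that something is new, unique, unknown or untested is made for them only; others in the source may bear on it.

- compound 1 `CC(C)C(=O)OCCc1c(-c2ccccc2Cl)c2cc(Cl)ccc2[nH]c1=O` gives 62000 nM in an ADME assay on HepG2 2.2.15 cells (Homo sapiens) for cytotoxicity; on this read-out higher numbers stand for lower toxicity in this test and lower numbers for higher toxicity in this test
- compound 2 `N#CCC(=O)OCCc1c(-c2ccccc2Cl)c2cc(Cl)ccc2[nH]c1=O` gives 100000 nM
- compound 3 `CC(=O)NCC(=O)OCCc1c(-c2ccccc2Cl)c2cc(Cl)ccc2[nH]c1=O` gives 110000 nM
- compound 4 `O=C(OCCc1c(-c2ccccc2Cl)c2cc(Cl)ccc2[nH]c1=O)C1CCCC1` is not yet measured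

Compound 3 stands level with the other two within the scatter. The measured steps are all small: a 1.8-fold higher number from compound 1 to compound 3 (0.25 log units; within the scatter), a 1.1-fold higher number from compound 2 to compound 3 (0.04 log units; within the scatter), and a 1.6-fold higher number from compound 1 to compound 2 (0.21 log units; within the scatter).

The next change is cyclopentyl in place of acetamidomethyl on a carbonyl carbon, with cyclopentyl in place of acetamidomethyl on a carbonyl carbon. Compound 1, with isopropyl at that place, is the closest measured case, and a 1.8-fold higher number from compound 1 to compound 3 (0.25 log units; within the scatter) sets the expected size. A small move to a lower number in this assay is expected, not clearly beyond the scatter. The expected change is a 1.7-fold lower number from compound 3 to compound 4 (0.23 log units; within the scatter). For compound 4 the estimated value is 65000 nM, with an expected range from 32000 nM to 120000 nM.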

Compound 4, half-maximal cytotoxic concentration: 46000 nM
The estimate for compound 4 lay 1.4-fold (0.15 log units) above the measured number; the range from low to high includes it.
By their numbers in this assay, from the lowest: compounds 4, 1, 2 and 3 (each within the scatter of the next, the first and the last beyond it).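

In this assay, among the compounds shown here, cyclopentyl on the carbonyl carbon gives the first steps at this position beyond the scatter: a 2.4-fold lower number from compound 3 to compound 4 (0.38 log units; beyond the scatter) and a 2.2-fold lower number from compound 2 to compound 4 (0.34 log units; beyond the scatter). Against isopropyl the same place shows only a 1.3-fold lower number from compound 1 to compound 4 (0.13 log units; within the scatter), so compound 4 and compound 1 stand level, while compound 1 also stays within the scatter of compound 2 and compound 3. Nothing at hand explains these steps.

On these data alone, whether a longer chain, an amine or a carboxylic acid on this carbonyl carbon would shift the number further remains open.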